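Trifluoromethyl on the aryl ether ring of compound 1

A few compounds are considered here, and "the series" means these few. Any claim that something is new, unique, unknown or untested is made for them only; others in the source may bear on it.

Compound 1 `Cc1ccc(Nc2nc(N)nc(COc3cccc(N4CCCC4=O)c3)n2)cc1Cl` sits at the low end of the numbers measured in an assay on COS-7 cells for agonist activity at Free fatty acid receptor 1 (Homo sapiens), read by scintillation counting and inositol phosphate accumulation, with a stated time of 90 min; on this read-out higher numbers stand for an effect only at larger amounts of compound and lower numbers for an effect already at smaller amounts: in this assay compound 1 gives 820 nM, compound 2 `Cc1ccc(Nc2nc(N)nc(COc3cccc(N4CCCS4(=O)=O)c3)n2)cc1Cl` gives 9700 nM and compound 3 `Cc1ccc(Nc2nc(N)nc(COc3cccc(N4CCCC4=O)c3C)n2)cc1Cl` gives 11100 nM. Both measured steps moved upward: a 12-fold higher number from compound 1 to compound 2 (1.07 log units; beyond the scatter) and a 14-fold higher number from compound 1 to compound 3 (1.13 log units; beyond the scatter). Compound 4 `Cc1ccc(Nc2nc(N)nc(COc3cc(N4CCCC4=O)cc(C(F)(F)F)c3)n2)cc1Cl` differs from compound 1 by trifluoromethyl in place of hydrogen on an aromatic carbon. Among the measured compounds shown here, the step bearing most on this is the one to compound 3, where a methyl entering the same aromatic ring gave a 14-fold higher number from compound 1 to compound 3 (1.13 log units; beyond the scatter); so a large upward step is expected in this assay for compound 4, a 7.3-fold higher number from compound 1 to compound 4 (0.86 log units; beyond the scatter), though the entering group and position differ, leaving the size uncertain. Compound 4 is estimated at 6000 nM, between 1500 nM and 25000 nM.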

Compound 4, half-maximal effective concentration: 3190 nM
For compound 4 the middle estimate is 1.9-fold (0.27 log units) above the measured one, within the range that was stated.
By their numbers in this assay, from the lowest: compound 1; then compound 4; then compounds 2 and 3 (each within the scatter of the next).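

In this assay, trifluoromethyl on this aromatic carbon, meta to the 2-oxopyrrolidin-1-yl group, gives a 3.9-fold higher number from compound 1 to compound 4 (0.59 log units; beyond the scatter). The change still raises the number beyond the scatter, but this step is modest, whereas both earlier steps from compound 1 were large. No measurement here accounts for the effect of this change.

The compounds shown leave open whether a single fluorine, a methoxy group or a carboxylic acid at this position would leave the number closer to that of compound 1 or move it further.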